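Adding a 4-Bromobenzyl to an Amide Nitrogen

The source may report more compounds than this note shows. Statements on the series, on what has been measured and on what is new or still open speak of the compounds shown alone.

Compound 2 `COC(=O)/C=C/c1cccc(NC(=O)C2CCCCC2)c1` is a secondary amide. In an assay on isolated protein with Bile acid receptor (Homo sapiens) as the target (a higher number here means that more compound is needed for the effect, a lower number that less compound is needed), compound 2 gives > 1000 nM, which is a limit of the assay rather than a number. Compound 1 `COC(=O)/C=C/c1cccc(N(Cc2ccc(-c3cccc(C)c3)cc2)C(=O)C2CCCCC2)c1`, which carries a large substituent on that nitrogen, gives 109 nM in this assay. Compound 3 `COC(=O)/C=C/c1cccc(N(Cc2ccc(Br)cc2)C(=O)C2CCCCC2)c1` differs from compound 2 by 4-bromobenzyl in place of hydrogen on an amide-type nitrogen. Within the data shown here, no pair of measured compounds differs by exactly this change. Compound 3 is expected to need less compound, because compound 1 gives 109 nM with a related substituent. The expected step is an at least 2.5-fold lower number from compound 2 to compound 3 (0.39 log units; beyond the scatter). Compound 3 is estimated at 400 nM, with a likely range from 100 nM to 2000 nM.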

Compound 3, half-maximal effective concentration: > 1000 nM
Compound 3 gave a limit, no number; the forecaster's own chance of this, stated with the estimate: 30%; at least 2.5-fold (0.39 log units) between middle value and limit.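

In this assay, bromo in place of 3-methylphenyl on an aromatic carbon gives an at least 9.1-fold higher number from compound 1 to compound 3 (0.96 log units; beyond the scatter). A benzyl group on the amide nitrogen is therefore not enough by itself, and in this pair the 3-methylphenyl is what separates a measured number from a limit. Compound 2 and compound 3 both stop at a limit, so the step between them cannot be read: the limit of > 1000 nM in this assay, at which 2 of the 3 values shown sit.

As far as these compounds go, it remains open whether a plain phenyl would do the same work as 3-methylphenyl, or whether the methyl matters. A pyridine ring or an amine at that place is equally untested among the compounds shown.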